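This account rests on a few compounds, and the source may have more. Where it says the series, first, only, none or still open, it means among the compounds named here.

In an ADME assay on microsomes from liver (Mus musculus) for metabolic stability, read by LC-MS, using NADPH, with stated times of 10 min and 60 min, tested at 0.1 uM (on this read-out lower numbers stand for a shorter-lived compound and higher numbers for a longer-lived compound), compound 1 (`COc1c(-c2ccc(F)cc2C)cc(S(=O)(=O)Nc2ccc(F)c(CC(=O)O)c2)c2ccccc12`) gives 1.47 h as the higher number. Going by the values given here, compound 2 (`COc1c(-c2ccccc2Cl)cc(S(=O)(=O)Nc2ccc(F)c(CC(=O)O)c2)c2ccccc12`) gives 0.718 h as the lowest of the two numbers so far. Among the compounds with values here, the only measured step (a 2.0-fold lower number from compound 1 to compound 2 (0.31 log units; beyond the scatter)) is modest and beyond the scatter: 2-chlorophenyl in place of 4-fluoro-2-methylphenyl on an aromatic carbon. Compound 3 (`COc1c(-c2ccccc2C(C)C)cc(S(=O)(=O)Nc2ccc(F)c(CC(=O)O)c2)c2ccccc12`) follows from compound 2 by one change (isopropyl in place of chloro on an aromatic carbon): isopropyl in place of chloro, on an aromatic carbon ortho to a large group. Within the data shown here, that earlier step is a loose guide, since it differs by more than the one group and no measured compound carries isopropyl. In this assay a small upward step is expected, no larger than the measured one and possibly within the scatter. The estimated step is small (a 1.2-fold higher number from compound 2 to compound 3 (0.07 log units; within the scatter)). For compound 3 the expected half-life is 0.85 h with an estimated range (0.35 h to 1.9 h).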

Compound 3, half-life: 0.252 h
For compound 3 the middle estimate is 3.4-fold (0.53 log units) above the measured one; the whole stated range lies above it.
By their numbers in this assay, from the lowest: compound 3; then compound 2; then compound 1.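

In this assay this position, ortho to a large group, proves more sensitive than the first pair suggested: isopropyl in place of chloro gives a 2.8-fold lower number from compound 2 to compound 3 (0.45 log units; beyond the scatter) and so does not preserve the number of the chloro compound. Across the whole aryl change, 2-isopropylphenyl in place of 4-fluoro-2-methylphenyl gives a 5.8-fold lower number from compound 1 to compound 3 (0.77 log units; beyond the scatter) and leaves compound 3 lowest of the three, with both its steps beyond the scatter. Nothing measured here speaks to the reason for this fall.

Still open, on these data alone, is how an amine or a methoxy group at this same position would compare with chloro and isopropyl. The shares of the fluoro and the methyl within the 4-fluoro-2-methylphenyl group of compound 1 also remain unseparated.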